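This account rests on a few compounds, and the source may have more. Where it says the series, first, only, none or still open, it means among the compounds named here.

Of the compounds shown here, two with the same core have been tested so far in a functional assay on U-937 cells (Homo sapiens) for antiproliferative activity, read by MTT assay, with a stated time of 24 h; a lower number here means a stronger inhibitor, a higher number a weaker inhibitor. Compound 1 (`CCCCc1oc2ccccc2c1C(=O)c1ccc(OCC(=O)NC(C)C)cc1`) gives 17500 nM. Compound 2 (`CCCCc1oc2ccccc2c1C(=O)c1ccc(OCC(=O)N2CCOCC2)cc1`) gives 45400 nM, the higher of the two numbers and so the weaker result. Compound 3 (`CCCCc1oc2ccccc2c1C(=O)c1ccc(OCC(=O)Nc2ccccc2)cc1`) keeps that core and differs from compound 2 at one place, with anilino in place of morpholin-4-yl on a carbonyl carbon.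

For the measured compounds named here, only one measured step bears on this change. Replacing isopropylamino with morpholin-4-yl at the same place gave a 2.6-fold higher number from compound 1 to compound 2 (0.41 log units; beyond the scatter), a modest step. Anilino, like the isopropylamino of compound 1 at 17500 nM, keeps the amide hydrogen that morpholin-4-yl lacks. Going by the values given here, a modest step back towards a lower number is therefore expected, though this rests on a single pair, and no compound with an aromatic ring at this place has been measured yet. The expected change is a 2.1-fold lower number from compound 2 to compound 3 (0.31 log units; beyond the scatter). For compound 3 the estimated value is 22000 nM, with an expected range of 8000 nM to 50000 nM.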

Compound 3, half-maximal inhibitory concentration: 25900 nM
Compound 3: the middle estimate sits 1.2-fold (0.07 log units) below what was measured; the measured number falls inside the stated range.
By their numbers in this assay, from the lowest: compounds 1, 3 and 2 (each within the scatter of the next, the first and the last beyond it).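

In this assay, for the compounds shown here, an aromatic ring now stands on this carbonyl carbon for the first time, and the swap of morpholin-4-yl for anilino gives (a 1.8-fold lower number from compound 2 to compound 3 (0.24 log units; within the scatter)), so this change cannot be told apart from repeat-to-repeat variation. Placing phenyl instead of isopropyl on the amide-type nitrogen gives (a 1.5-fold higher number from compound 1 to compound 3 (0.17 log units; within the scatter)), so these two groups cannot be separated either, and compound 3 shows that the amide hydrogen it shares with compound 1 does not, on its own, set a compound clearly apart from compound 2. No measured information is available to explain these numbers.

Going by these compounds alone, with only three groups at this place, the single step that exceeds the scatter, from compound 1 to compound 2, remains a thin basis for any trend. Still open, from the compounds shown here alone, is how a piperidin-1-yl group, which would differ from morpholin-4-yl only in its ring oxygen, or a benzylamino group, with a carbon spacer between the nitrogen and the phenyl ring, would compare with these three amides.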